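Bromo in place of butoxy: notes on the series

This account rests on a few compounds, and the source may have more. Where it says the series, first, only, none or still open, it means among the compounds named here.

Measured in a functional assay on MCF7 cells (Homo sapiens) for antiproliferative activity, read by sulforhodamine B assay, with a stated time of 48 h; on this read-out lower numbers stand for stronger inhibition and higher numbers for weaker inhibition:
- compound 1 `CCc1ccccc1NS(=O)(=O)c1ccc(N2CCNC2=O)cc1`: 350 nM
- compound 2 `O=C1NCCN1c1ccc(S(=O)(=O)Nc2ccc(F)cc2)cc1`: 690 nM
- compound 3 `CCCCOc1ccc(NS(=O)(=O)c2ccc(N3CCNC3=O)cc2)cc1`: 870 nM

Compound 3 stands at the upper end of these numbers. It lies within the scatter of compound 2, while compound 1 has a lower number, beyond the scatter. Next is compound 4 `O=C1NCCN1c1ccc(S(=O)(=O)Nc2ccc(Br)cc2)cc1`: bromo in place of butoxy on an aromatic carbon. This puts bromo in place of butoxy on an aromatic carbon, para to a large group. Among the measured compounds shown here, two measured steps bear on it: a 2.0-fold higher number from compound 1 to compound 2 (0.29 log units; within the scatter) and, closer still, a 1.3-fold higher number from compound 2 to compound 3 (0.10 log units; within the scatter). Both stay within the scatter, so no step beyond the scatter is expected in this assay. The estimated step is a 1.2-fold lower number from compound 3 to compound 4 (0.09 log units; within the scatter). Compound 4 is expected at 700 nM, with an estimated range of 300 nM to 1600 nM.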

Compound 4, half-maximal inhibitory concentration: 240 nM
For compound 4 the middle estimate is 2.9-fold (0.46 log units) above the measured one; the measured number lies below the stated range.
By their numbers in this assay, from the lowest: compounds 4, 1, 2 and 3 (each within the scatter of the next, the first and the last beyond it).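

At this position, para to a large group, changing the substituent now moves the number beyond the scatter in this assay, with bromo entering in both steps (a 3.6-fold lower number from compound 3 to compound 4 (0.56 log units; beyond the scatter); a 2.9-fold lower number from compound 2 to compound 4 (0.46 log units; beyond the scatter)). Fluoro and butoxy had stayed within the scatter of each other, so the separation appears only with bromo. On the sulfonamide nitrogen, 4-bromophenyl and 2-ethylphenyl remain within the scatter of each other (a 1.5-fold lower number from compound 1 to compound 4 (0.16 log units; within the scatter)). Nothing available accounts for these steps.

Open, from the compounds shown here alone, is whether chloro or iodo on the same carbon would match bromo. An amine or a carboxylic acid there also remains untested in the compounds shown.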